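Exchanging the ring on the thiocarbonyl carbon

This account rests on a few compounds, and the source may have more. Where it says the series, first, only, none or still open, it means among the compounds named here.

Compound 2, `Nc1ccccc1NC(=O)c1ccc(CSC(=S)N2CCc3ccccc32)cc1`, was tested in a functional assay on A-375 cells (Homo sapiens) for antiproliferative activity, read by CCK-8 assay, with a stated time of 72 h, tested at 8 uM (a higher number here means a stronger effect of the compound at the concentration tested, a lower number a weaker effect), where compound 2 gives 85.4%. Its two measured companions share the same core: compound 1, `Nc1ccccc1NC(=O)c1ccc(CSC(=S)N2CCN(Cc3ccccn3)CC2)cc1`, gives 82.4% in this assay, and compound 3, `Nc1ccccc1NC(=O)c1ccc(CSC(=S)N2CCN(c3ccc(F)cc3)CC2)cc1`, gives 76.3%. Compound 2 holds the numerically highest of the three values, but its gaps to compound 1 and to compound 3 both lie within the scatter, so no order among the three can be read from these numbers.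

Compound 4, `CC1CCN(C(=S)SCc2ccc(C(=O)Nc3ccccc3N)cc2)CC1`, differs from compound 2 in one place: 4-methylpiperidin-1-yl in place of 2,3-dihydro-1H-indol-1-yl on a thiocarbonyl carbon. Going by the values given here, the only measured single-point step, a number 6.1 percentage points lower from compound 1 to compound 3 (within the scatter), exchanges the substituent on an amine nitrogen in a ring rather than the ring on the thiocarbonyl carbon, so it bears only loosely on the present change; that step was small. With all three measured values lying within the scatter of one another, the record offers no ground to expect the exchange in compound 4 to move the number beyond the scatter in either direction. Compound 4 is accordingly expected to give 80% in this assay, with a range from 68% to 90%. The step of a number 5.4 percentage points lower from compound 2 to compound 4 (within the scatter) is estimated to stay within the scatter.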

Compound 4, a percentage reported as inhibition, at one concentration (the size of the read-out at that concentration, not a potency): 87.4%
Compound 4: the middle estimate sits 7.4 percentage points below what was measured, within the range that was stated.
By their numbers in this assay, from the lowest: compounds 3, 1, 2 and 4 (each within the scatter of the next, the first and the last beyond it).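

Exchanging 2,3-dihydro-1H-indol-1-yl for 4-methylpiperidin-1-yl on a thiocarbonyl carbon gives a number 2 percentage points higher from compound 2 to compound 4 (within the scatter) in this assay, and this is the only single change at this place among the compounds shown. The earlier step concerned a substituent on an amine nitrogen in a ring, whereas this one shows that the ring on the thiocarbonyl carbon itself can change without the number leaving the scatter, even though the six-membered aromatic ring of carbon only is lost and the entering group carries a single six-membered non-aromatic ring. Nothing shown explains this outcome.

Because the read-out comes from one concentration, it leaves open whether compound 2 and compound 4 would also stay within the scatter of each other in a measure of potency. It also leaves open whether the place tolerates groups of a different kind, such as an open-chain diethylamino group on the thiocarbonyl carbon or a carboxylic acid in place of the methyl on the piperidine ring.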